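From dimethylamino to ethylamino: what might compound 4 do?

The compounds below may be only part of what the source reports. "The series", "measured", "known", "first", "only" and "open" are said of these compounds alone.

Three related compounds have results so far in a functional assay on LS174T cells (Homo sapiens) for antiproliferative activity (on this read-out higher numbers stand for weaker inhibition and lower numbers for stronger inhibition), and two of them are plain numbers. Compound 1 (`CNc1ccc(/C=C/c2c(F)cccc2Cl)cc1`) gives 7.6 nM in this test. Compound 2 (`CNc1ccc(/C=C/c2c(Cl)cccc2Cl)cn1`) gives 19.6 nM in the same test.

Compound 3 (`CN(C)c1ncc(/C=C/c2c(F)cccc2F)cn1`) stands at > 200 nM and that result is a limit of the assay, not a number.

Compound 4 (`CCNc1ncc(/C=C/c2c(F)cccc2F)cn1`) has not been measured yet. It differs from compound 3 in one place, with ethylamino in place of dimethylamino on an aromatic carbon, between two ring nitrogen atoms (ethylamino in place of dimethylamino on an aromatic carbon). The two have the same atoms, joined differently.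

Going by the values given here, no measured pair of compounds isolates this kind of change, so any forecast is rough. Compound 1 (7.6 nM) and compound 2 (19.6 nM) each keep a hydrogen on their amino nitrogen, as compound 4 does, and so a move toward stronger inhibition is expected. Those two compounds also differ from compound 4 elsewhere, so only a moderate gain is expected and not a full match with them. The expected change is this (an at least 2.5-fold lower number from compound 3 to compound 4 (0.39 log units; beyond the scatter)). For compound 4 the estimated value is 80 nM in this assay with an expected range from 15 nM to 350 nM as its limits.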

Compound 4, half-maximal inhibitory concentration: > 200 nM
Compound 4: only a limit was reported; the forecaster's own chance of this, stated with the estimate: 30%; middle value at least 2.5-fold (0.39 log units) from the limit.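

No step can be read from compound 3 to compound 4 in this assay, because both results are limits of the assay and not numbers: the limit of > 200 nM in this assay, at which 2 of the 4 values shown sit.

The compounds shown leave open how strongly compound 3 and compound 4 really inhibit, and whether ethylamino in place of dimethylamino on an aromatic carbon changes inhibition at all.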